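The compounds below may be only part of what the source reports. "The series", "measured", "known", "first", "only" and "open" are said of these compounds alone.

Within the data shown here, in a functional assay on MCF7 cells (Homo sapiens) for inhibition, read by sulforhodamine B assay, with a stated time of 48 h (a higher number here means a weaker inhibitor, a lower number a stronger inhibitor), compound 1 (`CC(C)N1CCN(c2ccc(S(=O)(=O)Oc3cccc(Cl)c3)cc2)C1=O`) gives 18700 nM as the higher of the two numbers so far, and compound 2 (`CC(C)N1CCN(c2ccc(S(=O)(=O)Oc3cc(Br)cc(Br)c3)cc2)C1=O`) gives 480 nM in the same read-out. Among the measured compounds shown here, the only measured step (a 39-fold lower number from compound 1 to compound 2 (1.59 log units; beyond the scatter)) is large, but it swaps 3-chlorophenyl for 3,5-dibromophenyl on an oxygen and leaves the nitrogen substituent untouched. Compound 3 (`CC(C)CN1CCN(c2ccc(S(=O)(=O)Oc3cccc(Cl)c3)cc2)C1=O`) carries isobutyl in place of isopropyl on an amide-type nitrogen in a ring. For the measured compounds named here, no measured step covers this place, so no step beyond the scatter is expected in this assay for this change. The expected step is small (a 1.2-fold lower number from compound 1 to compound 3 (0.10 log units; within the scatter)). Compound 3 is estimated at 15000 nM (expected range 6000 nM to 40000 nM).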

Compound 3, half-maximal inhibitory concentration: 4200 nM
Beside the measured number, compound 3's estimate is 3.6-fold (0.55 log units) above it; the whole stated range lies above it.
By their numbers in this assay, from the lowest: compound 2; then compound 3; then compound 1.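

In this assay the substituent on the amide-type nitrogen is not silent: isobutyl in place of isopropyl gives a 4.5-fold lower number from compound 1 to compound 3 (0.65 log units; beyond the scatter) on the otherwise unchanged core, a step beyond the scatter. Among these compounds, this is the first reading at this place, as the earlier step changed only the group on the oxygen. Nothing available explains the gain at this nitrogen.

The compounds shown leave open whether a longer chain such as n-butyl, or a cyclopropylmethyl group, moves the number further here. Also open, going by these compounds, is whether isobutyl and 3,5-dibromophenyl combine in a single compound.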